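Swapping Hydroxymethyl for Methylcarbamoyl on Two Related Cores

A few compounds are considered here, and "the series" means these few. Any claim that something is new, unique, unknown or untested is made for them only; others in the source may bear on it.

Of the compounds shown here, three from one series have been measured in a physicochemical assay for lipophilicity, at pH 7.4; a higher number here means a more lipophilic compound, a lower number a more polar compound. Compound 1 `CNC(=O)c1cc(N)c(Nc2ccc(C#N)cc2)cc1Oc1c(C)cc(CCC#N)cc1C` gives 2.65 in this assay. Compound 2 `Cc1cc(CCC#N)cc(C)c1Oc1cc(Nc2ccc(C#N)cc2)c(N)cc1CO` gives 3.68 in the same assay. Compound 3 `Cc1cc(/C=C/C#N)cc(C)c1Oc1cc(Nc2ccc(C#N)cc2)c(N)cc1CO` gives 4.14, the highest of the three numbers, with every step to the other two beyond the scatter.

Two single changes connect the measured compounds. From compound 2 to compound 1 the change is methylcarbamoyl in place of hydroxymethyl on an aromatic carbon and the step it made is a number 1.03 log units lower from compound 2 to compound 1 (beyond the scatter). The two cores on which this change is seen differ as given by 2-cyanoethenyl in place of 2-cyanoethyl on an aromatic carbon, a change that on its own produced a number 0.46 log units higher from compound 2 to compound 3 (beyond the scatter).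

Compound 4 `CNC(=O)c1cc(N)c(Nc2ccc(C#N)cc2)cc1Oc1c(C)cc(/C=C/C#N)cc1C` has not yet been measured in this assay. It differs from compound 3 by methylcarbamoyl in place of hydroxymethyl on an aromatic carbon. Going by the values given here, this is the same change as the one made from compound 2 to compound 1, and its surroundings are described in identical words for both pairs, so it counts as the same change, occurring twice among the four compounds.

Because the earlier step of a number 1.03 log units lower from compound 2 to compound 1 (beyond the scatter) was large and beyond the scatter, a step of similar size is expected for compound 4, namely a number 1.04 log units lower from compound 3 to compound 4 (beyond the scatter). Among the compounds with values here, that expectation rests on a single measured pair, compound 2 and compound 1, and there is no second example to show whether the size carries over to the core of compound 3. Compound 4 is therefore estimated at 3.1, with a range from 2.7 to 3.5.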

Compound 4, partition coefficient: 4.12
Compound 4: middle estimate off by 1.02 log units, on the low side, and the stated range ends below it.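

On the core of compound 3, the replacement of hydroxymethyl by methylcarbamoyl gives a number 0.02 log units lower from compound 3 to compound 4 (within the scatter) in this assay, which leaves the two compounds indistinguishable, whereas the same replacement on the core of compound 2 gives a number 1.03 log units lower from compound 2 to compound 1 (beyond the scatter), so the size of the step did not carry over from one core to the other. The other side of the four-compound set tells the same story: the change from 2-cyanoethyl to 2-cyanoethenyl gives a number 1.47 log units higher from compound 1 to compound 4 (beyond the scatter) where methylcarbamoyl is present, against a number 0.46 log units higher from compound 2 to compound 3 (beyond the scatter) where hydroxymethyl is present, so in these four compounds the two changes do not act independently of each other. This rests on one pair per core, so it does not show which of the two results is the more typical of the series, and nothing among the data shown explains the difference between the cores.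

As far as these compounds go, it remains open whether other replacements for hydroxymethyl, such as a carboxylic acid or an aminomethyl group, would also give steps that differ between these two cores. From the compounds shown here alone, it is equally open how a longer chain in place of 2-cyanoethyl or 2-cyanoethenyl would behave alongside hydroxymethyl and methylcarbamoyl.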